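Lengthening the chain of compound 3 by one carbon

The source may hold more compounds than are shown below. What is called first, only, known or untested is meant among the compounds shown, and "the series" means these compounds.

Among the compounds with values here, in a functional assay on NCI-H1299 cells (Homo sapiens) for inhibition, read by CCK-8 assay, with a stated time of 72 h, tested at 10 uM (a higher number here means a stronger effect of the compound at the concentration tested, a lower number a weaker effect), compound 3 `CN(C)C(=O)c1cc2cnc(Nc3ccc(C(=O)NCCCCN=C=S)cc3O)nc2n1C1CCCC1` gives 51.8%, the lowest of the three numbers measured so far. Within the data shown here, compound 1 `CN(C)C(=O)c1cc2cnc(Nc3ccc(C(=O)NCCCCCN=C=S)cc3)nc2n1C1CCCC1` gives 76.5% and compound 2 `CN(C)C(=O)c1cc2cnc(Nc3ccc(C(=O)NCCCCCN=C=S)cc3F)nc2n1C1CCCC1` gives 86.7%; the only step measured between two closely related compounds, a number 10.2 percentage points higher from compound 1 to compound 2 (beyond the scatter), concerns the aromatic ring and so says nothing about a change in the chain. Compound 4 `CN(C)C(=O)c1cc2cnc(Nc3ccc(C(=O)NCCCCCN=C=S)cc3O)nc2n1C1CCCC1` differs from compound 3 by a group of 4 heavy atoms (2 carbon, 1 nitrogen, 1 sulfur; no ring) in place of a group of 3 heavy atoms (1 carbon, 1 nitrogen, 1 sulfur; no ring), on a saturated chain carbon, four bonds along the chain from an amide-type nitrogen. Among the measured compounds shown here, no measured pair isolates this change. Compound 1 shares the chain of compound 4 and stands well above compound 3, but it differs from compound 4 elsewhere, so the gap cannot be assigned to the chain alone. Compound 4 is therefore expected to land modestly above compound 3, at 62% with a range from 45% to 80%. The expected step is a number 10.2 percentage points higher from compound 3 to compound 4 (beyond the scatter).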

Compound 4, a percentage reported as inhibition, at one concentration (the size of the read-out at that concentration, not a potency): 80.7%
Compound 4: the middle estimate sits 18.7 percentage points below what was measured; measured number above the stated range.
By their numbers in this assay, from the lowest: compound 3; then compounds 1, 4 and 2 (each within the scatter of the next, the first and the last beyond it).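

With the hydroxy on the aromatic ring unchanged, the group of 4 heavy atoms in place of the group of 3 heavy atoms gives a number 28.9 percentage points higher from compound 3 to compound 4 (beyond the scatter) in this assay, so this chain change alone moves the result in this pair. On the longer chain, hydroxy in place of hydrogen gives a number 4.2 percentage points higher from compound 1 to compound 4 (within the scatter) and hydroxy in place of fluoro gives a number 6 percentage points lower from compound 2 to compound 4 (within the scatter) so the hydroxy makes no clear difference here. Nothing measured here explains these steps.

From the compounds shown here alone, whether a still longer chain would raise the number further stays open, and so does whether an amine on the aromatic carbon that carries the hydroxy would keep it.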